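The source may report more compounds than this note shows. Statements on the series, on what has been measured and on what is new or still open speak of the compounds shown alone.

Compound 1 `Nc1nc2c(c(-c3ccco3)cn2[C@@H]2O[C@H](CO)[C@@H](O)[C@H]2O)c(=O)[nH]1` was tested in a functional assay on HCT-116 cells (Homo sapiens), read by MTT assay, with a stated time of 72 h; a lower number here means a stronger inhibitor, a higher number a weaker inhibitor. In this assay compound 1 reaches only the limit of the assay, > 20000 nM, and no number is known for it. Compound 2 `O=c1[nH]cnc2c1c(-c1ccco1)cn2[C@@H]1O[C@H](CO)[C@@H](O)[C@H]1O` differs from it by hydrogen in place of amino on an aromatic carbon. In this assay compound 2 likewise returns only the limit, > 20000 nM. The step that the two limits leave unreadable from compound 1 to compound 2 therefore cannot be sized. Compound 3 `Cc1nc(N)c2c(I)cn([C@@H]3O[C@H](CO)[C@@H](O)[C@H]3O)c2n1` belongs to the same set. In this assay compound 3 also gives only the limit, > 20000 nM. So compound 1 stands nowhere in particular on the numbers shown: every value in hand is a limit, as the limit of > 20000 nM in this assay, at which 3 of the 3 values shown sit, records, and none of the shown compounds has a readable potency.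

Compound 4 `Nc1nc2c(c(-c3ccoc3)cn2[C@@H]2O[C@H](CO)[C@@H](O)[C@H]2O)c(=O)[nH]1` is not yet measured. The change from compound 1 is furan-3-yl in place of furan-2-yl on an aromatic carbon. No measured step in this set bears on that change, and the one step that is shown, from compound 1 to compound 2, cannot be read at all. Among the compounds with values here, with three compounds all sitting at the limit of the assay, the account can offer no direction for the step from compound 1 to compound 4 beyond the expectation that it stays unreadable; the estimate means a step that the limit leaves unreadable from compound 1 to compound 4. For compound 4 the expected value in this assay is 30000 nM, with a range from 10000 nM to 100000 nM, most probably reported again only as a limit.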

Compound 4, half-maximal inhibitory concentration: 17600 nM
The estimate for compound 4 lay 1.7-fold (0.23 log units) above the measured number; low and high end bracket the measured number.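

In this assay, within the data shown here, furan-3-yl in place of furan-2-yl gives an at least 1.1-fold lower number from compound 1 to compound 4 (0.05 log units; that floor lies within the scatter), the only step in the set that carries any size, and it is a floor only, so the true size remains unknown. Among these compounds, the two groups count the same atoms, donors and acceptors and differ only in how the furan ring is joined, yet this change at the carbon two ring bonds from the ring nitrogen gives the first readable number in the set, though a floor within the scatter cannot show how much the change matters. Compound 4 therefore gives the series a measured reference point, whereas compound 1, compound 2 and compound 3 each return only a limit: the limit of > 20000 nM in this assay, at which 3 of the 4 values shown sit.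

The step from compound 1 to compound 2 still cannot be read, so the compounds shown leave open what the amino group on the shared core contributes, including whether compound 4 would keep a readable number without it. They also leave open whether a thiophen-3-yl, a phenyl or an aminomethyl group at this same place would move the number further from the limit.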